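Swapping a sulfonamide for a hydroxy on a shared core

The compounds below may be only part of what the source reports. "The series", "measured", "known", "first", "only" and "open" are said of these compounds alone.

Compound 1 `CC(C)S(=O)(=O)Nc1cccc(N2CCN(Cc3cn(-c4ccccc4)nn3)CC2)c1` was tested in an assay on membranes from HEK293 cells for displacement of a labelled ligand from Sigma non-opioid intracellular receptor 1 (Homo sapiens), read by scintillation counting, with a stated time of 120 min; a higher number here means a weaker inhibitor, a lower number a stronger inhibitor; compound 1 gives < 100 nM, which is a limit of the assay rather than a number. Compound 2 `CC(C)S(=O)(=O)Nc1cccc(N2CCN(Cc3cn(-c4ccccc4F)nn3)CC2)c1` carries a fluoro in place of hydrogen on an aromatic carbon; in this assay compound 2 gives < 100 nM, again a limit. The step that the two limits leave unreadable from compound 1 to compound 2 cannot be read, since both of its ends are limits. Compound 3 `CC(C)S(=O)(=O)Nc1cccc(C2CCN(Cc3cn(-c4ccccc4)nn3)CC2)c1` shows the same picture: in this assay compound 3 gives < 100 nM, a limit and not a number. All three values therefore sit at the limit of < 100 nM in this assay, at which 3 of the 3 values shown sit, and the numbers shown do not place compound 3 more precisely than that.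

Compound 4 `Oc1cccc(C2CCN(Cc3cn(-c4ccccc4)nn3)CC2)c1` differs from compound 3 by hydroxy in place of (isopropylsulfonyl)amino on an aromatic carbon, a hydroxy in place of (isopropylsulfonyl)amino on an aromatic carbon. For the measured compounds named here, no measured step touches this change; the only step, from compound 1 to compound 2, concerns a different change and is itself unreadable. The expectation for compound 4 in this assay therefore rests on the limit alone and carries a wide range. The step that the limit leaves unreadable from compound 3 to compound 4 is expected to be modest, toward weaker binding. Compound 4 is expected to give about 80 nM, between 10 nM and 600 nM.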

Compound 4, inhibition constant: < 100 nM
Compound 4: no number, only a limit (the forecaster's own chance of this, stated with the estimate: 40%); the middle value is on the limit's open side.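

For the compounds shown here, compound 3 and compound 4 both give limits rather than numbers in this assay, so no step between them can be read: the limit of < 100 nM in this assay, at which 4 of the 4 values shown sit. The compounds shown leave open how strongly each one actually binds, and whether hydroxy in place of (isopropylsulfonyl)amino changes that at all.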